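Working notes on cytotoxicity across three measured analogues

A few compounds are considered here, and "the series" means these few. Any claim that something is new, unique, unknown or untested is made for them only; others in the source may bear on it.

Measured so far in a functional assay on HEL cells (Homo sapiens) for cytotoxicity, read by microscopy; a lower number here means that less compound is tolerated, a higher number that more compound is tolerated:
- Compound 1 `Cc1cn([C@@H]2O[C@H](CO[Si](C)(C)C(C)(C)C)[C@@]3(OS(=O)(=O)C=C3NCC(N)=O)[C@H]2O[Si](C)(C)C(C)(C)C)c(=O)n(C)c1=O`: compound 1 gives 16000 nM.
- Compound 2 `CCOC(=O)NC(=O)NC1=CS(=O)(=O)O[C@@]12[C@@H](CO[Si](C)(C)C(C)(C)C)O[C@@H](n1cc(C)c(=O)n(C)c1=O)[C@@H]2O[Si](C)(C)C(C)(C)C`: compound 2 gives 16000 nM.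
- Compound 3 `Cc1cn([C@@H]2O[C@H](CO[Si](C)(C)C(C)(C)C)[C@@]3(OS(=O)(=O)C=C3NCC(=O)OCc3ccccc3)[C@H]2O[Si](C)(C)C(C)(C)C)c(=O)n(C)c1=O`: for compound 3 only a limit is recorded, >= 400000 nM.

Compound 3 thus stands at the top of the numbers shown, and only as a limit (the limit of >= 400000 nM in this assay, at which 1 of the 3 values shown sits). The next compound, compound 4 `Cc1cn([C@@H]2O[C@H](CO[Si](C)(C)C(C)(C)C)[C@@]3(OS(=O)(=O)C=C3NCCC(=O)O)[C@H]2O[Si](C)(C)C(C)(C)C)c(=O)n(C)c1=O`, differs from compound 3 as follows: carboxymethyl in place of benzyloxycarbonyl on a saturated chain carbon bound to an amine nitrogen. Two measured steps lead into compound 3: an at least 25-fold higher number from compound 1 to compound 3 (1.39 log units; beyond the scatter) and an at least 25-fold higher number from compound 2 to compound 3 (1.39 log units; beyond the scatter). Both were large and both ran toward the limit, while compound 1 and compound 2 carry the more polar groups. Compound 4 carries a carboxymethyl group, so a drop from the limit is expected for compound 4, an at least 8.0-fold lower number from compound 3 to compound 4 (0.90 log units; beyond the scatter). Compound 4 is expected to give 50000 nM in this assay, between 10000 nM and 400000 nM.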

Compound 4, minimum cytotoxic concentration: 80000 nM
Compound 4: the middle estimate sits 1.6-fold (0.20 log units) below what was measured; the range from low to high includes it.
By their numbers in this assay, from the lowest: compounds 1 and 2 (each within the scatter of the next); then compound 4. At a limit, above all of these: compound 3.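

Replacing benzyloxycarbonyl with carboxymethyl on a saturated chain carbon bound to an amine nitrogen gives, in this assay, an at least 5.0-fold lower number from compound 3 to compound 4 (0.69 log units; beyond the scatter). Compound 3 remains only a limit: the limit of >= 400000 nM in this assay, at which 1 of the 4 values shown sits.
Carboxymethyl in place of carbamoyl gives a 5.0-fold higher number from compound 1 to compound 4 (0.70 log units; beyond the scatter), and 2-carboxyethyl in place of (ethoxycarbonyl)carbamoyl gives a 5.0-fold higher number from compound 2 to compound 4 (0.70 log units; beyond the scatter), so changes at this place produce a measured number that stands clear of compounds 1 and 2.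

As far as these compounds go, how far compound 3 truly stands from compound 4 remains open. Also open, from the compounds shown here alone, is how a methyl ester or a primary amine would read at this place.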